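The source may report more compounds than this note shows. Statements on the series, on what has been measured and on what is new or still open speak of the compounds shown alone.

Compound 1 `CCN(CC)CCNc1n[n+]([O-])c2ccc(Cl)cc2[n+]1[O-]`: 23000000 nM
Compound 2 `[O-][n+]1nc(NCCN2CCCCC2)[n+]([O-])c2cc(Cl)ccc21`: 3200000 nM
Compound 3 `CCN(CC)CCNc1n[n+]([O-])c2ccc(C(C)C)cc2[n+]1[O-]`: 45000000 nM

In a physicochemical assay for solubility, in the presence of a further agent that is not named here (a higher number here means a more soluble compound, a lower number a less soluble compound), compound 1 gives 23000000 nM. Compound 2 differs from compound 1 by piperidin-1-yl in place of diethylamino on a saturated chain carbon, two bonds along the chain from a nitrogen on an aromatic ring, and this change gave a 7.2-fold lower number from compound 1 to compound 2 (0.86 log units; beyond the scatter). Compound 3 differs from compound 1 by isopropyl in place of chloro on an aromatic carbon, which gave a 2.0-fold higher number from compound 1 to compound 3 (0.29 log units; within the scatter); in this assay compound 3 gives 45000000 nM.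

Compound 4 `CC(C)c1ccc2c(c1)[n+]([O-])c(NCCN1CCCCC1)n[n+]2[O-]` has not yet been measured in this assay. It differs from compound 3 by piperidin-1-yl in place of diethylamino on a saturated chain carbon, two bonds along the chain from a nitrogen on an aromatic ring, the same change that carried compound 1 to compound 2, made on the core of compound 3 rather than the core of compound 1. Because that earlier change gave a 7.2-fold lower number from compound 1 to compound 2 (0.86 log units; beyond the scatter), a step of comparable size is expected here, namely a 6.9-fold lower number from compound 3 to compound 4 (0.84 log units; beyond the scatter). On this basis compound 4 is estimated at 6500000 nM in this assay, expected to lie between 2000000 nM and 20000000 nM. Among the compounds with values here, only one prior instance of the change exists, so the expectation is tentative.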

Compound 4, solubility: 18000000 nM
Beside the measured number, compound 4's estimate is 2.8-fold (0.44 log units) below it, within the range that was stated.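

In this assay, piperidin-1-yl in place of diethylamino lowered the number again on the core of compound 3 (a 2.5-fold lower number from compound 3 to compound 4 (0.40 log units; beyond the scatter)), so the direction seen on the core of compound 1 carried over, although the step was smaller than the earlier one (a 7.2-fold lower number from compound 1 to compound 2 (0.86 log units; beyond the scatter)). The core difference also read differently with the two amines: isopropyl in place of chloro gave a step beyond the scatter with piperidin-1-yl (a 5.6-fold higher number from compound 2 to compound 4 (0.75 log units; beyond the scatter)), but one within it with diethylamino (a 2.0-fold higher number from compound 1 to compound 3 (0.29 log units; within the scatter)). These two cores show that the direction held in this set but establish no general size for the change, and no measurement shown explains the difference in size.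

The compounds shown leave open whether morpholin-4-yl or a longer chain, such as 3-(piperidin-1-yl)propyl, would move the number the same way. They also leave open how the change would read on a core carrying methoxy in place of chloro or isopropyl.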